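Swapping methylsulfonyl for nitro on a short ether chain

A few compounds are considered here, and "the series" means these few. Any claim that something is new, unique, unknown or untested is made for them only; others in the source may bear on it.

Compound 1, with structure `C[n+]1ccn(COCCCS(C)(=O)=O)c1/C=N/O`, was examined in a physicochemical assay for lipophilicity (on this read-out higher numbers stand for higher lipophilicity and lower numbers for lower lipophilicity), and gives -2.5. Two other compounds from the same series were measured alongside it. Among the measured compounds shown here, compound 2, `C[n+]1ccn(CCC[n+]2cccc(C(=O)c3ccccc3)c2)c1/C=N/O`, gives -2.62 in this assay, a reading that sits within the scatter of the one for compound 1, so the two cannot be told apart. Compound 3, `CN(CCCn1cc[n+](C)c1/C=N/O)S(=O)(=O)c1ccccc1`, gives -1.59, which lies clearly higher than compound 1, beyond the scatter. Among the three numbers the value of compound 1 is the second highest.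

Compound 4, `C[n+]1ccn(COCCC[N+](=O)[O-])c1/C=N/O`, has not yet been measured. It differs from compound 1 in one place: nitro in place of methylsulfonyl on a saturated chain carbon, three bonds along the chain from an oxygen on a saturated carbon. No measured pair among these three compounds shows this exchange, so the size of the step is open. The expectation is a modest rise in this assay, a step from compound 1 to compound 4 of about a number 0.60 log units higher from compound 1 to compound 4 (beyond the scatter), which would be beyond the scatter but not large. On that basis compound 4 is estimated at -1.9, with a likely range from -2.5 to -1.3.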

Compound 4, distribution coefficient: -2.65
Beside the measured number, compound 4's estimate is 0.75 log units above it, outside the stated range (below it).
By their numbers in this assay, from the lowest: compounds 4, 2 and 1 (each within the scatter of the next); then compound 3.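

Methylsulfonyl and nitro, exchanged on a saturated chain carbon three bonds along the chain from an oxygen on a saturated carbon, give in this assay a step of a number 0.15 log units lower from compound 1 to compound 4 (within the scatter). Among the compounds shown here, this is the first direct comparison at this position, and on this read-out the two groups cannot be told apart here, although they differ in their atoms and in the number of double bonds they carry. Nothing available accounts for this result.

Going by these compounds, whether the two groups would still read alike on a longer chain, or on a chain without the ether oxygen, remains open. The compounds shown also leave open what an amine or a carboxylic acid on this same carbon would give in this assay.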